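Swapping the ring on the amide-type nitrogen of compound 1

The source may report more compounds than this note shows. Statements on the series, on what has been measured and on what is new or still open speak of the compounds shown alone.

Compound 1 `O=C(NCCCCc1ccccc1)c1cccc(C2SCC(=O)N2c2ccccn2)c1` was tested in a functional assay on HOS-TE85 cells (Homo sapiens) for inhibition, read by CCK-8 assay, with a stated time of 72 h (a higher number here means a weaker inhibitor, a lower number a stronger inhibitor), where compound 1 gives 19.7 nM. Among the three measured compounds it stands second highest: compound 2 `COc1ccccc1N1C(=O)CSC1c1cc(C(=O)NCCCCc2ccccc2)cc(C2CC2)c1` gives 23.5 nM, a number that lies within the scatter of compound 1, and compound 3 `O=C(NCCCCc1ccccc1)c1cc(F)cc(C2SCC(=O)N2c2ccccn2)c1` gives 14.2 nM, again within the scatter. Among the measured compounds shown here, the one step between single-change neighbours, a 1.4-fold lower number from compound 1 to compound 3 (0.14 log units; within the scatter), is a fluoro in place of hydrogen on an aromatic carbon and does not touch the amide-type nitrogen in the ring.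

Compound 4 `CC(F)(F)c1cccc(N2C(=O)CSC2c2cccc(C(=O)NCCCCc3ccccc3)c2)c1` differs from compound 1 by a group of 10 heavy atoms (8 carbon, 2 fluorine; one six-membered aromatic ring of carbon only) in place of a group of 6 heavy atoms (5 carbon, 1 nitrogen; one six-membered aromatic ring with 1 hetero atom), on an amide-type nitrogen in a ring. For the measured compounds named here, no measured step alters this position alone; compound 2 carries a different aryl group on that nitrogen but also a cyclopropyl elsewhere, and its number sits within the scatter of compound 1. On that basis the expected change is none beyond the scatter, so compound 4 is estimated at 22 nM, between 9 nM and 55 nM, an expected step of a 1.1-fold higher number from compound 1 to compound 4 (0.05 log units; within the scatter).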

Compound 4, half-maximal inhibitory concentration in the HOS-TE85 assay: 29.1 nM
Estimate against measurement, compound 4: 1.3-fold (0.12 log units) below; low and high end bracket the measured number.
By their numbers in the HOS-TE85 assay, from the lowest: compounds 3, 1, 2 and 4 (each within the scatter of the next, the first and the last beyond it).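

In the HOS-TE85 assay, the change on the amide-type nitrogen gives a 1.5-fold higher number from compound 1 to compound 4 (0.17 log units; within the scatter), so this position accepts a larger group with a carbon-only aromatic ring in place of pyridin-2-yl without a step beyond the scatter. In a physicochemical assay for solubility, read by turbidimetry, measured as kinetic solubility, at pH 7.4 (a lower number here means a less soluble compound, a higher number a more soluble compound), however, compound 1 gives 20000 nM and compound 4 gives 2000 nM. The same change therefore leaves the number in the HOS-TE85 assay within the scatter while solubility falls, a cost that the inhibition numbers alone did not reveal: the measured solubility of compound 1, 20000 nM, and of compound 4, 2000 nM, a 10-fold lower number (1.00 log units; beyond the scatter)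

The compounds shown do not separate the loss of the ring nitrogen from the gain of the added carbon and fluorine atoms, as these change together. They also leave open whether a pyridin-2-yl ring carrying a morpholine on this nitrogen would keep the inhibition and recover the solubility.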